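The source may report more compounds than this note shows. Statements on the series, on what has been measured and on what is new or still open speak of the compounds shown alone.

Measured so far in a functional assay on K562 cells (Homo sapiens) for cytotoxicity, in the presence of a further agent that is not named here; on this read-out lower numbers stand for stronger inhibition and higher numbers for weaker inhibition:
compound 1 `Clc1ccc(-c2cc(-c3ccsc3)nc(-c3ccco3)c2)o1`, 22400 nM;
compound 2 `Clc1ccc(-c2cc(-c3ccoc3)cc(-c3cccs3)n2)cc1`, 21100 nM;
compound 3 `Clc1ccc(-c2cc(-c3ccoc3)cc(-c3ccsc3)n2)cc1`, 730 nM.

Compound 2 sits with compound 1, the two values lying within the scatter of each other, while compound 3 lies far below both. The one single-point step among these, a 29-fold lower number from compound 2 to compound 3 (1.46 log units; beyond the scatter), concerns the thiophene ring and not the furan. Compound 4 `Clc1ccc(-c2cc(-c3ccco3)cc(-c3cccs3)n2)cc1` differs from compound 2 by furan-2-yl in place of furan-3-yl on an aromatic carbon. Within the data shown here, no measured step touches the furan attachment, so the thiophene result is only a hint that moving an attachment point can matter greatly. The expectation for compound 4 in this assay is therefore uncertain, a step of a 2.1-fold lower number from compound 2 to compound 4 (0.32 log units; beyond the scatter), with an estimate of 10000 nM ranging from 1500 nM to 40000 nM.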

Compound 4, half-maximal inhibitory concentration: > 100000 nM
Compound 4: a limit, no number; the forecaster's own chance of this, stated with the estimate: 10%; middle value at least 10-fold (1.00 log units) away from the limit.
By their numbers in this assay, from the lowest: compound 3; then compounds 2 and 1 (each within the scatter of the next). At a limit, above all of these: compound 4.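

The earlier compounds shown here showed only that the thiophene attachment point matters; the furan attachment at this position, opposite the ring nitrogen, matters too. With the same atoms joined differently, furan-2-yl in place of furan-3-yl gives an at least 4.7-fold higher number from compound 2 to compound 4 (0.67 log units; beyond the scatter) in this assay. The value of compound 4 is a limit of the assay and not a number, so the true size of this step stays unknown: the limit of > 100000 nM in this assay, at which 1 of the 4 values shown sits.

The compounds shown leave open how furan-2-yl fares alongside thiophen-3-yl. They also leave open what an amine or a carboxylic acid would do at this position.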